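Replacing a dimethylphenyl amide with a tert-butylphenyl amide

This account rests on a few compounds, and the source may have more. Where it says the series, first, only, none or still open, it means among the compounds named here.

Measured compounds:
compound 1 `Cc1ccc(NC(=O)c2ncn(CC(=O)NCc3ccc4[nH]ncc4c3)n2)cc1C`, 36900 nM
compound 2 `Cc1ccc(NC(=O)c2ncn(CC(=O)NCc3ccc4c(N)nccc4c3)n2)cc1C`, 69200 nM
compound 3 `Cc1ccc(NC(=O)c2ncn(CC(=O)NCCn3cnc4[nH]ccc4c3=O)n2)cc1C`, 138000 nM

Of the compounds shown here, three sharing one core have been tested in an assay for inhibition of histone-lysine N-methyltransferase, H3 lysine-79 specific (Homo sapiens), read by luminescence, with a stated time of 1 h; a higher number here means a weaker inhibitor, a lower number a stronger inhibitor. Compound 1 gives 36900 nM, the lowest of the three numbers. Compound 2 gives 69200 nM, which sits within the usual scatter of the value for compound 1, so no order between the two can be claimed. Compound 3 gives 138000 nM, a number that lies beyond the scatter from compound 1, so compound 3 is the weaker of that pair in this assay.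

Compound 4 `CC(C)(C)c1ccc(NC(=O)c2ncn(CC(=O)NCc3ccc4[nH]ncc4c3)n2)cc1` has not yet been tested. It differs from compound 1 in one place: 4-(tert-butyl)phenyl in place of 3,4-dimethylphenyl on an amide-type nitrogen. Among the compounds with values here, no pair among the measured compounds shows the effect of such a change on the amide nitrogen, so nothing in the data favours a move in either direction. Compound 4 is therefore expected to stay close to compound 1, with the step from compound 1 to compound 4 estimated as a 1.1-fold higher number from compound 1 to compound 4 (0.04 log units; within the scatter), that is, no step beyond the scatter. The value for compound 4 is estimated at 40000 nM, with a range from 12000 nM to 130000 nM.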

Compound 4, half-maximal inhibitory concentration: 22400 nM
For compound 4 the middle estimate is 1.8-fold (0.25 log units) above the measured one; the range from low to high includes it.
By their numbers in this assay, from the lowest: compounds 4, 1, 2 and 3 (each within the scatter of the next, the first and the last beyond it).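

In this assay, placing 4-(tert-butyl)phenyl in place of 3,4-dimethylphenyl on the amide-type nitrogen gives a 1.6-fold lower number from compound 1 to compound 4 (0.22 log units; within the scatter) and so allows no order between the two compounds. Within the data shown here, the earlier compounds all carry 3,4-dimethylphenyl and differ only elsewhere, so this is the first pair to vary this position, and it shows that a group of 10 heavy atoms in place of one of 8 brings no change that can be told from the scatter. Nothing at hand explains how these two groups compare in this assay.

As far as these compounds go, it remains open whether an amine or a carboxylic acid on the phenyl ring of this amide, or a longer alkyl chain in place of the tert-butyl group, would move the number beyond the scatter. Also open, from the compounds shown here alone, is whether 4-(tert-butyl)phenyl would behave the same way on compound 2 and compound 3.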